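A few compounds are considered here, and "the series" means these few. Any claim that something is new, unique, unknown or untested is made for them only; others in the source may bear on it.

Compound 1 `COc1cc(/C=C2\CN(C)C/C(=C\c3ccccc3F)C2=O)cc(OC)c1OC`: 640 nM
Compound 2 `COc1cc(/C=C2\CN(C)C/C(=C\c3ccc(F)cc3)C2=O)cc(OC)c1`: 5040 nM

Both values come from a functional assay on THP-1 cells (Homo sapiens) for cytotoxicity, read by MTT assay, with a stated time of 24 h; on this read-out lower numbers stand for stronger inhibition and higher numbers for weaker inhibition. Compound 2 holds the higher of the two numbers, and its gap to compound 1 lies beyond the scatter.

Compound 3 `COc1cc(/C=C2\CN(C)C/C(=C\c3cccc([N+](=O)[O-])c3)C2=O)cc(OC)c1` differs from compound 2 by 3-nitrophenyl in place of 4-fluorophenyl on a double-bonded chain carbon bound to a double-bonded ring carbon. Among the compounds with values here, no measured pair isolates this change, so the expectation is loose. With compound 2 at 5040 nM, the top of the two numbers, a modest step to a lower number in this assay is expected: a 2.3-fold lower number from compound 2 to compound 3 (0.36 log units; beyond the scatter). For compound 3 the estimated value is 2200 nM, with an expected range of 650 nM to 7000 nM.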

Compound 3, half-maximal inhibitory concentration: 1770 nM
Compound 3: the middle estimate sits 1.2-fold (0.09 log units) above what was measured; the range from low to high includes it.
By their numbers in this assay, from the lowest: compound 1; then compound 3; then compound 2.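

In this assay, within the data shown here, replacing 4-fluorophenyl with 3-nitrophenyl on a double-bonded chain carbon bound to a double-bonded ring carbon gives a 2.8-fold lower number from compound 2 to compound 3 (0.45 log units; beyond the scatter) as the first single-place step. This position can therefore move the number beyond the scatter, and here the larger group gives the lower number. Nothing measured here explains the step. The compounds shown do not separate the effect of the nitro group from that of its ring position. As far as these compounds go, how an amine or a carboxylic acid would read in this place also remains open.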